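The compounds below may be only part of what the source reports. "The series", "measured", "known", "first", "only" and "open" are said of these compounds alone.

Measured compounds:
compound 1, `Cn1nc2c(=O)n(CC3(O)CCN(Cc4ccc(-c5ccco5)cc4Cl)CC3)cnc2c1-c1ccc(C(N)=O)cc1`: 80.8 nM
compound 2, `Cn1nc2c(=O)n(CC3(O)CCN(Cc4ccc(-c5ccncc5)cc4Cl)CC3)cnc2c1-c1ccc(CN)cc1`: 257 nM

Both numbers come from an assay on isolated protein for inhibition of ubiquitin carboxyl-terminal hydrolase 7 (Homo sapiens), with stated times of 30 min and 2 h; on this read-out higher numbers stand for weaker inhibition and lower numbers for stronger inhibition. Compound 1 holds the lower number of the two; the number for compound 2 lies beyond the scatter above it. Compound 2 differs from compound 1 in more than one place, so the two values alone do not show which of its changes carries the gap.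

Compound 3, `Cn1nc2c(=O)n(CC3(O)CCN(Cc4ccc(-c5ccco5)cc4Cl)CC3)cnc2c1-c1ccc(CN)cc1`, is not yet measured. It differs from compound 1 in a single place: aminomethyl in place of carbamoyl on an aromatic carbon. Within the data shown here, no measured pair isolates this change. Among the measured compounds shown here, the only measured compound carrying the aminomethyl group is compound 2, which in this assay gives 257 nM, and its second change is not separated from the first. The step from compound 1 to compound 3 is therefore expected to run toward a higher number, of modest size and possibly within the scatter.

Compound 3 is expected to give 150 nM, in a range of 55 nM to 420 nM. This estimate means an expected step of a 1.9-fold higher number from compound 1 to compound 3 (0.27 log units; within the scatter).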

Compound 3, half-maximal inhibitory concentration: 18.1 nM
Compound 3: the middle estimate sits 8.3-fold (0.92 log units) above what was measured; measured number outside the range, below it.
By their numbers in this assay, from the lowest: compound 3; then compound 1; then compound 2.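

In this assay, aminomethyl in place of carbamoyl, on an aromatic carbon para to a large group, now stands isolated with the furan-2-yl group held fixed: it gives a 4.5-fold lower number from compound 1 to compound 3 (0.65 log units; beyond the scatter), so this position favours the aminomethyl group over the carbamoyl group in this pair. Compound 3 also separates the other change carried by compound 2: with aminomethyl held fixed, furan-2-yl in place of pyridin-4-yl gives a 14-fold lower number from compound 2 to compound 3 (1.15 log units; beyond the scatter), so the weaker inhibition of compound 2 goes with its pyridin-4-yl group and not with its aminomethyl group. Nothing shown here gives a reason for either step.

The compounds shown leave open whether a longer chain such as 2-aminoethyl, a substituted amine such as dimethylaminomethyl, or a carboxylic acid at the same position would go beyond the aminomethyl group. They also leave open whether the aminomethyl step holds with pyridin-4-yl in place of furan-2-yl, and whether a thiophene or plain phenyl group would serve as well as furan-2-yl.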